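The source may report more compounds than this note shows. Statements on the series, on what has been measured and on what is new or still open speak of the compounds shown alone.

In a functional assay on B16-F10 cells (Mus musculus) for antiproliferative activity, read by ELISA and MTT assay, with a stated time of 48 h (a higher number here means a weaker inhibitor, a lower number a stronger inhibitor), compound 1 `Cc1ccc(S(=O)(=O)NC(=O)/C=C/c2ccc(F)cc2)cc1` gives 4.8 ug/mL, and compound 2 `O=C(/C=C/c1ccc(F)cc1)NS(=O)(=O)c1ccc(Br)cc1` gives 2.8 ug/mL. Going by the values given here, compound 2 stands at the lower end of the two numbers, but the only measured step, a 1.7-fold lower number from compound 1 to compound 2 (0.23 log units; within the scatter), is within the scatter, so compound 2 cannot be called the stronger inhibitor on these data. Compound 3 `O=C(/C=C/c1ccc(Br)cc1)NS(=O)(=O)c1ccc(Br)cc1` has not yet been measured. It differs from compound 2 in one place: bromo in place of fluoro on an aromatic carbon. Among the compounds with values here, the single measured step, a 1.7-fold lower number from compound 1 to compound 2 (0.23 log units; within the scatter), concerns bromo in place of methyl rather than in place of fluoro, and it did not move the number beyond the scatter; no measured pair shows the exchange of fluoro for bromo. For compound 3 the expected step is a 1.1-fold lower number from compound 2 to compound 3 (0.03 log units; within the scatter), a change within the scatter. The estimate for compound 3 in this assay is 2.6 ug/mL, with a range from 1.2 ug/mL to 5.5 ug/mL.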

Compound 3, half-maximal inhibitory concentration: 5.1 ug/mL
Compound 3: middle estimate off by 2.0-fold (0.29 log units), on the low side, within the range that was stated.
By their numbers in this assay, from the lowest: compounds 2, 1 and 3 (each within the scatter of the next).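

In this assay, going by these compounds alone, the exchange of 4-fluorophenyl for 4-bromophenyl gives a 1.8-fold higher number from compound 2 to compound 3 (0.26 log units; within the scatter), the first measured reading of this change on an aromatic carbon para to a large group. Like the different exchange of methyl for bromo in a 1.7-fold lower number from compound 1 to compound 2 (0.23 log units; within the scatter), it stays within the scatter, so in this assay the two compounds cannot be told apart and this position accepts bromo as well as fluoro on the evidence of this one pair. No measurement at hand explains these numbers.

From the compounds shown here alone, whether an amine, a methoxy group or a carboxylic acid at this place would move the number beyond the scatter stays open. So does whether the same exchange of fluoro for bromo would give a like step on the core of compound 1.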